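Cyano in Place of Methoxycarbonyl: Expected Binding Strength

A few compounds are considered here, and "the series" means these few. Any claim that something is new, unique, unknown or untested is made for them only; others in the source may bear on it.

Compound 1 `O=C(CCCCCCc1ccccc1)c1ccc(-c2ccco2)nn1` and compound 2 `COC(=O)c1cccc(-c2ccc(C(=O)CCCCCCc3ccccc3)nn2)n1` share the same core and differ at a single aromatic position. In an assay for inhibition of Fatty-acid amide hydrolase 1 (Rattus norvegicus), at pH 9.0 (a higher number here means a weaker inhibitor, a lower number a stronger inhibitor), compound 1 gives 40 nM, while compound 2 gives 110 nM. Among the compounds with values here, compound 2 thus stands at the highest of the two numbers measured so far, and the step of a 2.8-fold higher number from compound 1 to compound 2 (0.44 log units; beyond the scatter) sets the size of that gap. Compound 3 `N#Cc1cccc(-c2ccc(C(=O)CCCCCCc3ccccc3)nn2)n1` has not yet been measured. It differs from compound 2 by one change: cyano in place of methoxycarbonyl on an aromatic carbon. Within the data shown here, no measured step bears on this particular swap, since the only step recorded concerns a different replacement on the shared core. With nothing to point in either direction, the expectation for the step of a 1.2-fold lower number from compound 2 to compound 3 (0.09 log units; within the scatter) is a change that stays within the scatter. Compound 3 is therefore estimated to give 90 nM in this assay, with a range from 30 nM to 270 nM.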

Compound 3, inhibition constant: 390 nM
The estimate for compound 3 lay 4.3-fold (0.64 log units) below the measured number, and the stated range ends below it.
By their numbers in this assay, from the lowest: compound 1; then compound 2; then compound 3.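

In this assay, the group on this aromatic carbon, next to the ring nitrogen, clearly matters: cyano in place of methoxycarbonyl gives a 3.5-fold higher number from compound 2 to compound 3 (0.55 log units; beyond the scatter), so this swap weakens binding by more than the usual scatter. Against the furan-2-yl group of the first compound, 6-cyanopyridin-2-yl gives a 9.8-fold higher number from compound 1 to compound 3 (0.99 log units; beyond the scatter), the widest gap among these three compounds, and both pyridinyl groups give higher numbers than furan-2-yl. Nothing available explains why this swap weakens binding.

As far as these compounds go, whether a carboxylic acid, an amide or an amine at this same position would give a lower or a higher number remains open. Also open, from the compounds shown here alone, is whether cyano in place of methoxycarbonyl would have the same effect on a compound with a shorter chain at the carbonyl.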